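Azido replaces hydroxy on the core of compound 1

The source may hold more compounds than are shown below. What is called first, only, known or untested is meant among the compounds shown, and "the series" means these compounds.

Compound 1 `C=C(C)[C@@H]1CC=C(CN(OC)C2O[C@H](CO)[C@@H](N=[N+]=[N-])[C@H](O)[C@H]2O)CC1` gives 22000 nM
Compound 2 `C=C(C)[C@@H]1CC=C(CN(OC)C2O[C@@H](CO)[C@H](N=[N+]=[N-])[C@@H](O)[C@@H]2O)CC1` gives 263000 nM

In a functional assay on PC-3 cells (Homo sapiens) for cytotoxicity, read by resazurin assay, with a stated time of 48 h (a higher number here means a weaker inhibitor, a lower number a stronger inhibitor), compound 1 gives 22000 nM and so holds the lower of the two numbers, the stronger result. Compound 3 (`C=C(C)[C@@H]1CC=C(CN(OC)C2O[C@H](CN=[N+]=[N-])[C@@H](N=[N+]=[N-])[C@H](O)[C@H]2O)CC1`) keeps the core of compound 1 but carries azido in place of hydroxy on a saturated chain carbon bound to a saturated ring carbon. Going by the values given here, the only measured step (a 12-fold higher number from compound 1 to compound 2 (1.08 log units; beyond the scatter)) alters configuration and leaves atoms and bonds untouched, so it does not speak directly to this swap. Among the compounds with values here, no measured step covers hydroxymethyl to azidomethyl, so only a modest change of uncertain direction is expected, which keeps the estimate close to compound 1 (22000 nM). The expected change is a 1.2-fold lower number from compound 1 to compound 3 (0.09 log units; within the scatter) in size. Compound 3 is estimated at 18000 nM with an expected range from 5000 nM to 70000 nM in this measurement.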

Compound 3, half-maximal inhibitory concentration: 57000 nM
For compound 3 the middle estimate is 3.2-fold (0.50 log units) below the measured one, and the stated range covers the measured number.
By their numbers in this assay, from the lowest: compound 1; then compound 3; then compound 2.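

In this assay, going by these compounds alone, this is the first step that changes atoms rather than configuration, and replacing the hydroxymethyl of compound 1 with azidomethyl gives a 2.6-fold higher number from compound 1 to compound 3 (0.41 log units; beyond the scatter). The step is modest but lies beyond the scatter, so the hydroxy on this saturated chain carbon matters to the reading, yet a measurable number remains without it. Nothing measured here explains why this swap gives a higher number.

One step removes the hydroxy and brings in the azido together, so the compounds shown cannot separate the loss of one group from the arrival of the other. An aminomethyl or a methoxymethyl group at this place could help to tell these apart, and the same swap on compound 2 would show whether the step holds in that configuration.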